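Compound 4 in the HCC827 Antiproliferative Series

This account rests on a few compounds, and the source may have more. Where it says the series, first, only, none or still open, it means among the compounds named here.

Measured compounds:
compound 1 `CC(C)n1c([S+]([O-])c2ccccc2)nc2cnc(Nc3ccc(N4CCN(C)CC4)cc3)nc21`, 215 nM
compound 2 `CN1CCN(c2ccc(Nc3ncc4nc(Sc5ccccc5)n([C@H]5CC[C@H](O)CC5)c4n3)cc2)CC1`, 42.6 nM
compound 3 `CN1CCN(c2ccc(Nc3ncc4nc(Sc5ccccc5)n(C5CCCC5)c4n3)cc2)CC1`, 51.2 nM

Of the compounds shown here, three have been measured in a functional assay on HCC827 cells (Homo sapiens) for antiproliferative activity, read by MTT assay, with a stated time of 72 h; on this read-out lower numbers stand for stronger inhibition and higher numbers for weaker inhibition. Compound 1 `CC(C)n1c([S+]([O-])c2ccccc2)nc2cnc(Nc3ccc(N4CCN(C)CC4)cc3)nc21` gives 215 nM, compound 2 `CN1CCN(c2ccc(Nc3ncc4nc(Sc5ccccc5)n([C@H]5CC[C@H](O)CC5)c4n3)cc2)CC1` gives 42.6 nM, and compound 3 `CN1CCN(c2ccc(Nc3ncc4nc(Sc5ccccc5)n(C5CCCC5)c4n3)cc2)CC1` gives 51.2 nM. Compound 3 stands second highest of the three numbers; its nearest neighbour is compound 2, within the scatter, and compound 1 is furthest from it, beyond the scatter.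

For the measured compounds named here, the single measured step on the aromatic nitrogen is a 1.2-fold higher number from compound 2 to compound 3 (0.08 log units; within the scatter), showing that a change of the substituent there left the number essentially unchanged. Compound 4 `CC(C)n1c(Sc2ccccc2)nc2cnc(Nc3ccc(N4CCN(C)CC4)cc3)nc21` continues along this nitrogen: isopropyl in place of cyclopentyl on an aromatic nitrogen. Compound 1 also carries isopropyl on that nitrogen, but it differs from compound 4 elsewhere, so its number cannot be tied to this change alone.

Given the flat step from compound 2 to compound 3, the expectation for compound 4 is a step of a 1.8-fold higher number from compound 3 to compound 4 (0.24 log units; within the scatter), slightly upward, with the number for compound 4 estimated at 90 nM and expected to fall between 40 nM and 220 nM.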

Compound 4, half-maximal inhibitory concentration: 290 nM
The estimate for compound 4 lay 3.2-fold (0.51 log units) below the measured number; measured number outside the range, above it.
By their numbers in this assay, from the lowest: compounds 2 and 3 (each within the scatter of the next); then compounds 1 and 4 (each within the scatter of the next).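

In this assay, the substituent on the aromatic nitrogen proves not to be indifferent: isopropyl in place of cyclopentyl gives the step of a 5.7-fold higher number from compound 3 to compound 4 (0.75 log units; beyond the scatter) and isopropyl in place of 4-hydroxycyclohexyl gives the step of a 6.8-fold higher number from compound 2 to compound 4 (0.83 log units; beyond the scatter) while the two ring-bearing groups stand level, with the step of a 1.2-fold higher number from compound 2 to compound 3 (0.08 log units; within the scatter) inside the scatter. On the aromatic carbon, with isopropyl held on the nitrogen, phenylsulfanyl in place of the group of 8 heavy atoms that carries oxygen and sulfur gives the step of a 1.3-fold higher number from compound 1 to compound 4 (0.13 log units; within the scatter) and leaves the two compounds level, so this change shows no measurable separation here. Nothing available explains why the isopropyl compound separates from the two ring-bearing compounds.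

The compounds shown leave open whether a ring on this nitrogen or only its carbon count goes with the lower numbers, a question that cyclopropyl, a straight pentyl chain or unsubstituted cyclohexyl would address. They also leave open whether the group on the aromatic carbon behaves the same way with cyclopentyl on the nitrogen, and how a phenylsulfonyl group there would compare.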